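The source may report more compounds than this note shows. Statements on the series, on what has been measured and on what is new or still open speak of the compounds shown alone.

The three measured compounds and their values in this single-concentration read-out:

compound 1, `CN1CCN(c2ccc(-c3cc4[nH]nc(N)c4c(=O)[nH]3)cc2)CC1`, 11%
compound 2, `Cc1cc2c(c(N)nn2C)c(N2CCCCC2)n1`, 17%
compound 3, `Cc1cc2c(c(N)nn2C)c(N2CC[C@H](O)C2)n1`, 1%

In an assay on isolated protein for inhibition of MAP kinase-activated protein kinase 5 (Homo sapiens), read by mobility shift assay, tested at 30 uM (on this read-out higher numbers stand for more inhibition at the one concentration tested (going by the name of the read-out) and lower numbers for less inhibition), compound 3 stands lowest of the three numbers. Its nearest neighbour is compound 1, whose value lies within the usual scatter of it, so no order can be read between those two. Within the data shown here, compound 2 is the furthest away, and the one measured step that reaches compound 3 is a number 16 percentage points lower from compound 2 to compound 3 (beyond the scatter), a modest fall that is beyond the scatter.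

Compound 4 is `COCCNc1nc(C)cc2c1c(N)nn2C`. It differs from compound 3 in one place: (2-methoxyethyl)amino in place of 3-hydroxypyrrolidin-1-yl on an aromatic carbon. Among the measured compounds shown here, the only measured step that bears on this place is the step from compound 2 to compound 3, which also exchanged the group on that same aromatic carbon, and it was modest in size. For the measured compounds named here, no measured pair exchanges a five-membered ring for a group with no ring, so the direction of the present change is not fixed by the data. Since compound 3 already sits at the bottom of the set, a fall much further is hardly possible, and a rise would be expected to be small at most. Compound 4 is therefore expected to stay within the scatter of compound 3, with a step of about a number 7 percentage points higher from compound 3 to compound 4 (within the scatter), giving an estimate of 8% in the range 0% to 22%.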

Compound 4, a percentage reported as inhibition, at one concentration (the size of the read-out at that concentration, not a potency): 5%
For compound 4 the middle estimate is 3 percentage points above the measured one; measured number inside the range.
By their numbers in this assay, from the lowest: compounds 3, 4, 1 and 2 (each within the scatter of the next, the first and the last beyond it).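

In this assay, the ring of compound 3 can give way to a group with no ring at this aromatic carbon next to the ring nitrogen without a change that stands out, since the result is a number 4 percentage points higher from compound 3 to compound 4 (within the scatter). The second replacement of piperidin-1-yl also lands beyond the scatter, at a number 12 percentage points lower from compound 2 to compound 4 (beyond the scatter), so among these three compounds piperidin-1-yl stands apart from both oxygen-bearing groups, a five-membered ring with a hydroxyl and a chain with a methoxy end, and neither compound 3 nor compound 4 goes against this. Nothing available explains these numbers or ties them to any property of the groups.

The compounds shown leave open whether it is the oxygen that separates these groups from piperidin-1-yl, a question that a plain pyrrolidin-1-yl or a butylamino chain at the same carbon would bear on directly. They also leave open how a morpholin-4-yl or a 4-methylpiperazin-1-yl group would read there, and whether any group at this place would give more than the small inhibition seen so far at the single concentration tested.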